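Phenyl for Benzofuranyl: Expecting Compound 4

The source may report more compounds than this note shows. Statements on the series, on what has been measured and on what is new or still open speak of the compounds shown alone.

Compound 1 `COc1nc(N)nc2c1c(-c1cc3ccccc3o1)cn2[C@@H]1O[C@H](CO)[C@@H](O)[C@H]1O` is the only one of the three measured compounds to give a number: in a functional assay on CCRF-CEM cells (Homo sapiens), read by MTT assay, with a stated time of 72 h (a lower number here means a stronger inhibitor, a higher number a weaker inhibitor), compound 1 gives 12700 nM. Compound 2 `Nc1nc(N)c2c(-c3cc4ccccc4o3)cn([C@@H]3O[C@H](CO)[C@@H](O)[C@H]3O)c2n1` is reported only as a limit of this assay, > 20000 nM. Compound 3 `Nc1nc(N)c2c(-c3ccoc3)cn([C@@H]3O[C@H](CO)[C@@H](O)[C@H]3O)c2n1` likewise reaches only the limit > 20000 nM. The step of an at least 1.5-fold higher number from compound 1 to compound 2 (0.19 log units; that floor lies within the scatter) and the step that the two limits leave unreadable from compound 2 to compound 3 therefore offer little guidance. Compound 4 `COc1nc(N)nc2c1c(-c1ccccc1)cn2[C@@H]1O[C@H](CO)[C@@H](O)[C@H]1O` differs from compound 1 by phenyl in place of 1-benzofuran-2-yl on an aromatic carbon. For the measured compounds named here, none of the measured steps changes this group starting from a numbered value, so neither direction nor size can be read from them. The expectation for compound 4 is therefore a step of a 1.2-fold higher number from compound 1 to compound 4 (0.07 log units; within the scatter) that need not exceed the scatter, estimated at 15000 nM with a range from 5000 nM to 40000 nM.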

Compound 4, half-maximal inhibitory concentration: > 20000 nM
Compound 4 was reported as a limit; the forecaster's own chance of this, stated with the estimate: 35%; at least 1.3-fold (0.12 log units) between middle value and limit.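

For the compounds shown here, putting phenyl in place of 1-benzofuran-2-yl is the first change at this aromatic carbon that starts from a numbered value, and it gives an at least 1.5-fold higher number from compound 1 to compound 4 (0.19 log units; that floor lies within the scatter). From the compounds shown here alone, compound 4 is reported only as a limit, so the true size of this step stays unknown and even its floor does not show a real loss. Phenyl brings no visible gain in this assay, and the values crowd at one ceiling: the limit of > 20000 nM in this assay, at which 3 of the 4 values shown sit.

Going by these compounds, whether any group at this carbon could give a clearly lower number than compound 1 remains open. A pyridin-2-yl ring or a simple amine here might give a readable value.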